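This account rests on a few compounds, and the source may have more. Where it says the series, first, only, none or still open, it means among the compounds named here.

Measured so far in a functional assay on A549 cells (Homo sapiens) for cytotoxicity, read by MTT assay, with a stated time of 72 h (a lower number here means a stronger inhibitor, a higher number a weaker inhibitor), are three compounds:

Compound 1 `COc1ccc(-c2ccnc(Nc3cccc(S(N)(=O)=O)c3)n2)cc1` gives 1600 nM
Compound 2 `NS(=O)(=O)c1cccc(Nc2nccc(-c3ccccc3)n2)c1` gives 200 nM
Compound 3 `CS(=O)(=O)c1ccc(-c2ccnc(Nc3cccc(C(N)=O)c3)n2)cc1` gives > 100000 nM

Compound 3 has no actual number in this assay and stands only at the limit of > 100000 nM in this assay, at which 1 of the 3 values shown sits, as its result. Compound 4 `CS(=O)(=O)c1ccc(-c2ccnc(Nc3cccc(S(N)(=O)=O)c3)n2)cc1` differs from compound 3 in one place, sulfamoyl in place of carbamoyl on an aromatic carbon and the rest of the structure stays the same.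

For the measured compounds named here, no measured step makes this swap directly. Going by the values given here, the only measured step is an 8.0-fold lower number from compound 1 to compound 2 (0.90 log units; beyond the scatter) and it is a modest one, with hydrogen in place of methoxy on an aromatic carbon. It bears on the question only indirectly. Compound 1 and compound 2 both carry the sulfamoyl group that compound 4 gains, and both give real numbers. However, compound 4 keeps the group that compound 3 has at the site where compound 1 has methoxy, and its contribution has not been measured separately.

A step to a lower number, beyond the scatter, is therefore expected in this assay but its size is poorly fixed. The estimated change is an at least 20-fold lower number from compound 3 to compound 4 (1.30 log units; beyond the scatter) and it rests on very little data. Compound 4 is expected to read 5000 nM with 600 nM to 40000 nM as the estimated range.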

Compound 4, half-maximal inhibitory concentration: > 100000 nM
Compound 4: no number, only a limit; the forecaster's own chance of this, stated with the estimate: 15%; at least 20-fold (1.30 log units) between middle value and limit.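

In this assay compound 4 gives > 100000 nM, which is a limit of the assay and not a number. Compounds 1, 2 and 4 all carry the sulfamoyl group and differ only at the other end of the molecule, so this result shows how much that second site matters: methylsulfonyl in place of hydrogen gives an at least 500-fold higher number from compound 2 to compound 4 (2.69 log units; beyond the scatter) and methylsulfonyl in place of methoxy gives an at least 62-fold higher number from compound 1 to compound 4 (1.79 log units; beyond the scatter) in this series. Sulfamoyl in place of carbamoyl therefore does not bring a methylsulfonyl compound back to a readable value, and the step between compound 3 and compound 4 cannot be read, so nothing can be said about the size of that swap, and the two methylsulfonyl compounds both end at the same ceiling: the limit of > 100000 nM in this assay, at which 2 of the 4 values shown sit.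

From the compounds shown here alone, whether carbamoyl and sulfamoyl differ at all remains open, since the carbamoyl group appears only in compound 3, which also carries methylsulfonyl, and a carbamoyl compound with hydrogen at the second site would be needed to compare them. Going by these compounds, it is also open how other groups at the second site, such as an amine, a carboxylic acid or a fluorine atom, would read.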